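This account rests on a few compounds, and the source may have more. Where it says the series, first, only, none or still open, it means among the compounds named here.

Measured so far in a functional assay on A549 cells (Homo sapiens) for antiproliferative activity, read by MTT assay, with a stated time of 72 h; a higher number here means a weaker inhibitor, a lower number a stronger inhibitor: compound 1 `CCC/C=C/C(=O)Nc1cc2c(N3CCc4ccccc43)ncnc2cc1OC` gives 2920 nM; compound 2 `CCC/C=C/C(=O)Nc1cc2c(N3CCc4ccccc43)ncnc2cc1O[C@@H]1CCOC1` gives 9110 nM; compound 3 `COc1cc2ncnc(N3CCCc4ccccc43)c2cc1NC(=O)C=C(C)C` gives 5410 nM.

Within the data shown here, the one single-point step in this set runs from compound 1 to compound 2, where oxolan-3-yl in place of methyl on an oxygen on an aromatic ring brought a 3.1-fold higher number from compound 1 to compound 2 (0.49 log units; beyond the scatter). Compound 3 shares the same atoms as compound 1, joined differently; the difference between the two cores is not broken down here, and the values of compound 3 and compound 1 lie within the usual scatter of each other.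

Compound 4 `CC(C)=CC(=O)Nc1cc2c(N3CCCc4ccccc43)ncnc2cc1O[C@@H]1CCOC1` is not yet measured. It differs from compound 3 by oxolan-3-yl in place of methyl on an oxygen on an aromatic ring, the same change made from compound 1 to compound 2, at the same place. On that single precedent, compound 4 is expected to show a 2.8-fold higher number from compound 3 to compound 4 (0.44 log units; beyond the scatter), a step of about the size seen from compound 1 to compound 2, because the change there gave a 3.1-fold higher number from compound 1 to compound 2 (0.49 log units; beyond the scatter). The estimate for compound 4 in this assay is 15000 nM, with a range from 6000 nM to 38000 nM.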

Compound 4, half-maximal inhibitory concentration: 7910 nM
For compound 4 the middle estimate is 1.9-fold (0.28 log units) above the measured one; measured number inside the range.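

In this assay, oxolan-3-yl in place of methyl on the oxygen gave a 1.5-fold higher number from compound 3 to compound 4 (0.16 log units; within the scatter), a step that stays within the scatter on this core. Set beside the earlier step on the other core, the size of the change does not differ measurably: the same change on two cores in this assay, a 3.1-fold higher number (0.49 log units; beyond the scatter) from compound 1 to compound 2 and a 1.5-fold higher number (0.16 log units; within the scatter) from compound 3 to compound 4, 2.1-fold (0.33 log units) apart, within the scatter of two such steps. Among these compounds, this shows that the two cores are compatible with one shared step, but it does not establish that the step is the same on both or that it would hold on a further core, as only one of the two steps lies beyond the scatter.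

The compounds shown leave open how a longer alkoxy chain or an ether carrying an amine would compare with methoxy and (oxolan-3-yl)oxy on either core. They also leave open what the opposite configuration at the oxolan-3-yl stereocentre would give.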